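Ethyl to benzyl ester in a series at its limit

This account rests on a few compounds, and the source may have more. Where it says the series, first, only, none or still open, it means among the compounds named here.

Measured in a functional assay on Jurkat cells (Homo sapiens) for cytotoxicity, with a stated time of 72 h (on this read-out higher numbers stand for an effect only at larger amounts of compound and lower numbers for an effect already at smaller amounts), each entry a limit:
- Compound 1 `C=C[C@@](C)(/C=C/c1ccc(O)cc1)CCC=O`: > 49000 nM
- Compound 2 `C=C[C@@](C)(/C=C/c1ccc(O)cc1)CCCO`: > 49000 nM
- Compound 3 `C=C[C@@](C)(/C=C/c1ccc(O)cc1)CC/C=C/C(=O)OCC`: > 49000 nM

Going by the values given here, the series so far shows (the limit of > 49000 nM in this assay, at which 3 of the 3 values shown sit). Compound 3 stands with its peers, and its > 49000 nM is a limit and not a number.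

The next compound is compound 4 `C=C[C@@](C)(/C=C/c1ccc(O)cc1)CC/C=C/C(=O)OCc1ccccc1`. The change is phenyl in place of methyl on a saturated chain carbon bound to an oxygen next to a carbonyl group, or ethoxy to benzyloxy.

Among the compounds with values here, no measured step touches this place. The nearest are a step that the two limits leave unreadable from compound 1 to compound 3, a step that the two limits leave unreadable from compound 2 to compound 3 and a step that the two limits leave unreadable from compound 1 to compound 2, and none of them has a readable size. With no size to carry over, the expectation rests on compound 3 alone.

No shift in a known direction is expected in this assay, and the estimated step is a number no higher from compound 3 to compound 4 (the limit leaves the size open). Another limit reading is the likeliest outcome. For compound 4 the expected value is 49000 nM, with an estimated range from 20000 nM to 100000 nM.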

Compound 4, half-maximal effective concentration: > 49000 nM
Compound 4: a limit, no number (the forecaster's own chance of this, stated with the estimate: 65%); the middle value sits exactly at the limit.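

Compound 4 gives > 49000 nM in this assay, a limit and not a number. The ethoxy to benzyloxy change from compound 3 to compound 4 therefore has no readable size. The compounds shown leave open what size any change on this chain has, the whole series resting on one reading: the limit of > 49000 nM in this assay, at which 4 of the 4 values shown sit.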